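Demethylation on a saturated carbon in a polyether scaffold

The source may hold more compounds than are shown below. What is called first, only, known or untested is meant among the compounds shown, and "the series" means these compounds.

Compound 2, with structure `COC1=C(OC)[C@@]2(OC)c3c(O)c(OC)c4c(c3O[C@@]23O[C@@H](c2ccccc2)CC=C3C1=O)[C@@H](OC)C[C@H](c1ccccc1)O4`, is measured in a functional assay on P388 cells (Homo sapiens) for cytotoxicity against P388 (Mus musculus) (on this read-out lower numbers stand for an effect already at smaller amounts and higher numbers for an effect only at larger amounts of compound), and gives 0.78 ug/mL. Among the two compounds measured so far it stands at the higher number: compound 1, with structure `COC1=C(OC)[C@@]2(OC)c3c(OC)c(OC)c4c(c3O[C@@]23O[C@@H](c2ccccc2)CC=C3C1=O)[C@@H](OC)C[C@H](c1ccccc1)O4`, gives 0.2 ug/mL in this assay, and the step of a 3.9-fold higher number from compound 1 to compound 2 (0.59 log units; beyond the scatter) arose from hydrogen in place of methyl on an oxygen on an aromatic ring.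

Compound 3, with structure `COC1=C(OC)[C@@]2(OC)c3c(O)c(OC)c4c(c3O[C@@]23O[C@@H](c2ccccc2)CC=C3C1=O)[C@@H](O)C[C@H](c1ccccc1)O4`, is the next step away from compound 2. The change is hydrogen in place of methyl on an oxygen on a saturated carbon; cut one bond further out, it reads methoxy to hydroxy, here on an oxygen on a saturated carbon whose other neighbour is a saturated ring carbon.

Among the compounds with values here, the one step that bears on this is the step from compound 1 to compound 2, where removal of a methyl from an oxygen gave a modest rise beyond the scatter. That step concerned an oxygen on an aromatic ring, not a saturated carbon, so its size is only a loose guide. A modest rise in the number is therefore expected for compound 3, the step of a 2.1-fold higher number from compound 2 to compound 3 (0.31 log units; beyond the scatter) being estimated as similar or smaller. Compound 3 is expected to give about 1.6 ug/mL in this assay, with a likely range from 0.4 ug/mL to 6 ug/mL.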

Compound 3, half-maximal effective concentration: 0.42 ug/mL
Beside the measured number, compound 3's estimate is 3.8-fold (0.58 log units) above it; low and high end bracket the measured number.
By their numbers in this assay, from the lowest: compound 1; then compounds 3 and 2 (each within the scatter of the next).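

In this assay, the exchange of methyl for hydrogen on an oxygen on a saturated carbon gives a 1.9-fold lower number from compound 2 to compound 3 (0.27 log units; within the scatter), so on this read-out methoxy and hydroxy at this position cannot be told apart in this pair. The earlier compounds shown here showed the same exchange only on an oxygen on an aromatic ring, where a 3.9-fold higher number from compound 1 to compound 2 (0.59 log units; beyond the scatter) lay beyond the scatter, so the two places do not respond alike here, and the size of the aromatic step does not carry over to the saturated carbon. No measurement is available that would account for this difference between the two places.

The compounds shown leave open how this position would respond to other groups on the saturated carbon, such as an ethoxy group, an acetate ester or an amine, since only methoxy and hydroxy are compared here. They also leave open whether methoxy to hydroxy at this position would read the same in a compound that keeps the methoxy on the aromatic ring, as compound 1 does, since the exchange is seen here only with compound 2 as the starting point.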